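The source may hold more compounds than are shown below. What is called first, only, known or untested is meant among the compounds shown, and "the series" means these compounds.

In a functional assay on CCRF-CEM cells (Homo sapiens) for antiproliferative activity, read by fluorescence and resazurin assay, with a stated time of 48 h (a lower number here means a stronger inhibitor, a higher number a weaker inhibitor), compound 2 `Cc1noc(NS(=O)(=O)c2ccc(NC(=O)c3cc4ccccc4oc3=O)cc2)c1C` gives 26600 nM and compound 1 `Cc1noc(NS(=O)(=O)c2ccc(NC(=O)c3cc4ccc(O)cc4oc3=O)cc2)c1C` gives 21500 nM within the scatter of that number, while compound 3 `O=C(N/N=C/c1ccncc1)c1cc2cc([N+](=O)[O-])ccc2oc1=O` gives the lower 13000 nM on a different structure. Compound 4 `Cc1noc(NS(=O)(=O)c2ccc(NC(=O)c3cc4cc([N+](=O)[O-])ccc4oc3=O)cc2)c1C` differs from compound 2 by nitro in place of hydrogen on an aromatic carbon with nitro in place of hydrogen on an aromatic carbon. Among the measured compounds shown here, the one measured step on this core, hydrogen in place of hydroxy, is small at a 1.2-fold higher number from compound 1 to compound 2 (0.09 log units; within the scatter) and concerns another group. For the measured compounds named here, compound 3 at 13000 nM also carries nitro, but no measured step isolates that group. No step beyond the scatter is therefore expected in this assay but only a slight lean to a lower number, with a 1.5-fold lower number from compound 2 to compound 4 (0.17 log units; within the scatter) as the estimated step. The estimated value of compound 4 is 18000 nM with an expected range from 8000 nM to 40000 nM as its bounds.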

Compound 4, half-maximal inhibitory concentration: 14300 nM
The estimate for compound 4 lay 1.3-fold (0.10 log units) above the measured number; the measured number falls inside the stated range.
By their numbers in this assay, from the lowest: compounds 3, 4, 1 and 2 (each within the scatter of the next, the first and the last beyond it).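

In this assay, among the compounds shown here, the step of a 1.9-fold lower number from compound 2 to compound 4 (0.27 log units; within the scatter) gives the first measured reading for nitro on the shared core, and it shows that nitro on this aromatic carbon, meta to a fused ring and para to a fused ring, stays within the scatter of hydrogen. Nothing available bears on what lies behind this step. The compounds shown leave open whether an amine or a carboxylic acid on this same carbon would shift the number beyond the scatter, and whether nitro on another carbon of that ring would do so.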